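Methoxy in Place of Chloro on a Benzyl Ether Tail

This account rests on a few compounds, and the source may have more. Where it says the series, first, only, none or still open, it means among the compounds named here.

Three thymidine-derived ureas have been examined in an ADME assay on MRC5 cells (Homo sapiens) for cytotoxicity; a higher number here means that more compound is tolerated, a lower number that less compound is tolerated. Compound 1 `Cc1cn([C@@H]2C[C@H](O)[C@@H](CNC(=O)Nc3ccc(OC4CCOCC4)cc3)O2)c(=O)[nH]c1=O` carries an oxan-4-yl group on the aryl ether oxygen; in this assay compound 1 gives only a limit, > 50000 nM. Compound 2 `Cc1cn([C@@H]2C[C@H](O)[C@@H](CNC(=O)Nc3ccc(OCc4cccc(Cl)c4)cc3)O2)c(=O)[nH]c1=O` carries a 3-chlorobenzyl group there; in this assay compound 2 likewise gives only a limit, > 50000 nM. Compound 3 `Cc1cn([C@@H]2C[C@H](O)[C@@H](CNC(=O)Nc3ccc(OCc4ccc(Cl)cc4)cc3)O2)c(=O)[nH]c1=O` carries a 4-chlorobenzyl group; in this assay compound 3 again gives only a limit, > 50000 nM. The steps between them, a step that the two limits leave unreadable from compound 1 to compound 2, a step that the two limits leave unreadable from compound 1 to compound 3 and a step that the two limits leave unreadable from compound 2 to compound 3, therefore cannot be sized, because of the limit of > 50000 nM in this assay, at which 3 of the 3 values shown sit.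

Compound 4 `COc1ccc(COc2ccc(NC(=O)NC[C@H]3O[C@H](n4cc(C)c(=O)[nH]c4=O)C[C@@H]3O)cc2)cc1` differs from compound 3 by methoxy in place of chloro on an aromatic carbon. Among the compounds with values here, no measured step bears on this change, and none of the three measured steps has a readable size, so nothing beyond the scatter is expected. The step from compound 3 to compound 4 is estimated as a number no higher from compound 3 to compound 4 (the limit leaves the size open). Compound 4 is therefore expected to give about 50000 nM, most probably again only a limit, within a range from 20000 nM to 100000 nM.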

Compound 4, half-maximal cytotoxic concentration: > 50000 nM
Compound 4: no number, only a limit (the forecaster's own chance of this, stated with the estimate: 85%); the middle value lies on the limit itself.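

Compound 4 gives only a limit in this assay, so its steps from compound 1, compound 2 and compound 3 cannot be read, because all the values share one limit: the limit of > 50000 nM in this assay, at which 4 of the 4 values shown sit.

The compounds shown leave open how these four compounds compare in cytotoxicity, and which change, if any, would yield a measurable number.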